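This account rests on a few compounds, and the source may have more. Where it says the series, first, only, none or still open, it means among the compounds named here.

Among the measured compounds shown here, compound 2, `CCC(C)(C)Cc1c[nH]c(CCc2ccc(-c3cccnc3)cc2)n1`, stands at 4.3 nM in a functional assay on HEK293 cells for agonist activity at Bombesin receptor subtype-3 (Mus musculus), read by luminescence and calcium flux, with a stated time of 10 min (on this read-out lower numbers stand for an effect already at smaller amounts and higher numbers for an effect only at larger amounts of compound), the lower of the two numbers measured so far; its nearest neighbour is compound 1, `CCC(C)(C)Cc1c[nH]c(CCc2ccc(-n3ccnn3)cc2)n1`, which gives 57 nM in this assay. For the measured compounds named here, the one measured step, a 13-fold lower number from compound 1 to compound 2 (1.12 log units; beyond the scatter), exchanges the whole aromatic ring attached to the shared core and lies well beyond the scatter.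

Compound 3, `CCC(C)(C)Cc1c[nH]c(CCc2ccc(-c3cccnc3C(=O)O)cc2)n1`, keeps the pyridinyl ring of compound 2 and differs from it only in one place: carboxy in place of hydrogen on an aromatic carbon, set next to the ring nitrogen and ortho to a large group. Going by the values given here, no measured step touches a substituent on this ring, so the large size of the step from compound 1 to compound 2 gives no direct guide to the new change; it only shows that this region of the molecule is sensitive in this assay.

On that footing compound 3 is expected to give a higher number than compound 2, with an estimated step of a 9.3-fold higher number from compound 2 to compound 3 (0.97 log units; beyond the scatter). The expected value for compound 3 is 40 nM, within a range from 6 nM to 300 nM.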

Compound 3, half-maximal effective concentration: 14 nM
The estimate for compound 3 lay 2.9-fold (0.46 log units) above the measured number; the range from low to high includes it.
By their numbers in this assay, from the lowest: compound 2; then compound 3; then compound 1.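

In this assay the aromatic carbon next to the ring nitrogen and ortho to a large group accepts a substituent with only a limited shift: carboxy in place of hydrogen gives a 3.3-fold higher number from compound 2 to compound 3 (0.51 log units; beyond the scatter) and stays beyond the scatter. Among the compounds shown here, that step is smaller than the exchange of the whole ring, a 13-fold lower number from compound 1 to compound 2 (1.12 log units; beyond the scatter) and so the earlier compounds, which showed only that the ring matters, gave no measure of what a substituent on the retained ring does. The 2-carboxypyridin-3-yl ring still holds part of the advantage of pyridin-3-yl over 1H-1,2,3-triazol-1-yl, with a 4.1-fold lower number from compound 1 to compound 3 (0.61 log units; beyond the scatter) as the step in that direction. Nothing available here bears on why the number moves with this change.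

On these data alone, whether this shift belongs to the carboxylic acid itself or to any group at this place stays open, and a methyl ester, a primary amide or an amine at the same carbon would separate those readings. The compounds shown also leave open how carboxy would read on the other carbons of this ring, or on the 1H-1,2,3-triazol-1-yl ring of compound 1.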